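Swapping the Aryl Group and Expected Permeability

This account rests on a few compounds, and the source may have more. Where it says the series, first, only, none or still open, it means among the compounds named here.

Three related compounds have been tested in an ADME assay on Caco-2 cells (Homo sapiens) for permeability, in the apical to basolateral direction; on this read-out lower numbers stand for lower permeability and higher numbers for higher permeability. Compound 1 `CNC(=O)c1cc(Oc2ccc3nc(Nc4cccc(C(C)(C)C)c4)ccc3c2)ccn1` gives a reading that is only a limit of the assay, < 1 10^-6 cm/s. Compound 2 `CNC(=O)c1cc(Oc2ccc3nc(Nc4cccc(C(C)(C)C)c4)cnc3c2)ccn1` likewise gives only a limit, < 1 10^-6 cm/s. Compound 3 `CNC(=O)c1cc(Oc2ccc3nc(Nc4cccc(C(F)(F)F)c4)ncc3c2)ccn1` also returns a limit rather than a number, < 1 10^-6 cm/s. Compound 3 therefore stands where every measured compound stands, at the limit of < 1 10^-6 cm/s in this assay, at which 3 of the 3 values shown sit, and no difference between the three can be read from these numbers.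

Compound 4 `CNC(=O)c1cc(Oc2ccc3nc(Nc4ccc(OC(F)(F)F)cc4)ncc3c2)ccn1` has not yet been measured in this assay. It differs from compound 3 in one place: 4-(trifluoromethoxy)phenyl in place of 3-(trifluoromethyl)phenyl on a nitrogen on an aromatic ring. Among the compounds with values here, no step between measured compounds is available to show how such a change moves permeability here, and with all three readings at the same limit there is nothing to suggest the change would carry compound 4 beyond the scatter. For compound 4 the expected value in this assay is 0.8 10^-6 cm/s, within a range of 0.3 10^-6 cm/s to 3 10^-6 cm/s. The expected step that the limit leaves unreadable from compound 3 to compound 4 is small. Most likely compound 4 will again be reported only as a limit.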

Compound 4, apparent permeability: < 1 10^-6 cm/s
Compound 4: no number, only a limit; the forecaster's own chance of this, stated with the estimate: 70%; the middle value is on the limit's open side.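

No step can be read between compound 3 and compound 4, since both readings are limits of the assay, and the same holds across the series: the limit of < 1 10^-6 cm/s in this assay, at which 4 of the 4 values shown sit.

From the compounds shown here alone, how far these compounds truly differ in this assay, and whether swapping the aryl group moves the reading at all, stays open.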